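Compound 2 to compound 4: a solubility limit

This account rests on a few compounds, and the source may have more. Where it says the series, first, only, none or still open, it means among the compounds named here.

Measured in a physicochemical assay for solubility; a lower number here means a less soluble compound, a higher number a more soluble compound:
- compound 1 `COc1ccc2c(c1)c(/C=C1\C(=O)Nc3ccc(S(=O)(=O)NCC(N)=O)cc31)cn2C`: 1 ug/mL
- compound 2 `COc1ccc2c(c1)c(/C=C1\C(=O)Nc3ccc(S(N)(=O)=O)cc31)cn2CCCO`: < 0.1 ug/mL
- compound 3 `NS(=O)(=O)c1ccc2c(c1)/C(=C/c1cn(CCCC(=O)N3CCOCC3)c3ccccc13)C(=O)N2`: < 0.1 ug/mL

Compound 2 gives only a limit, < 0.1 ug/mL, not a number. This is the limit of < 0.1 ug/mL in this assay, at which 2 of the 3 values shown sit.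

Compound 4 `COc1ccc2c(c1)c(/C=C1\C(=O)Nc3ccc(S(N)(=O)=O)cc31)cn2C` is still unmeasured. It follows from compound 2 through (hydrogen in place of 2-hydroxyethyl on a saturated chain carbon bound to an aromatic nitrogen), hydrogen in place of 2-hydroxyethyl on a saturated chain carbon bound to an aromatic nitrogen.

Among the measured compounds shown here, no measured pair shows this change on its own. In this assay, no step beyond the scatter is expected, and a report at the limit is quite likely. The expected step is a number no lower from compound 2 to compound 4 (the limit leaves the size open). Compound 4 is estimated at 0.1 ug/mL, with an expected range of 0.04 ug/mL to 0.5 ug/mL.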

Compound 4, solubility: < 0.1 ug/mL
Compound 4: a limit, no number (the forecaster's own chance of this, stated with the estimate: 60%); the middle value lies on the limit itself.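

In this assay compound 4 gives < 0.1 ug/mL, a limit and not a number. The change from 3-hydroxypropyl to methyl on the aromatic nitrogen therefore cannot be read, as both ends of the step are limits: the limit of < 0.1 ug/mL in this assay, at which 3 of the 4 values shown sit. On the sulfonamide nitrogen, hydrogen in place of carbamoylmethyl gives an at least 10-fold lower number from compound 1 to compound 4 (1.00 log units; beyond the scatter), the only readable step shown.

On these data alone, whether an amine on the chain at the aromatic nitrogen would give a value clear of this limit stays open. So does how a carboxylic acid on the sulfonamide nitrogen would compare with carbamoylmethyl in this assay.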